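Working notes on rat clearance: compound 1 to compound 3

This account rests on a few compounds, and the source may have more. Where it says the series, first, only, none or still open, it means among the compounds named here.

Measured compounds:
- compound 1 `Cc1cc(Cl)cc(-c2ccnc3cc(CN4C(=O)CCC4=O)sc23)c1O[C@H]1C[C@H](N)C1`: "not determined" (no result reported) in an ADME assay on the whole organism (Rattus norvegicus, strain Sprague-Dawley) for pharmacokinetics, at a dose of 0.5 mg/kg by the intravenous route; a higher number here means faster removal of the compound, a lower number slower removal
- compound 2 `O=C1CCC(=O)N1Cc1cc2nccc(-c3cc(Cl)cc4c3O[C@@H](c3onc5c3CNCC5)C4)c2s1`: 96.7 mL/min/kg

In this assay, among the compounds with values here, compound 2 gives 96.7 mL/min/kg, a single point and the only number in the set. Compound 1 stands nowhere on the numbers shown: for compound 1 this assay reports "not determined" (no result reported), so its clearance is unknown. Compound 3 `Cc1cc(Cl)cc(-c2ccnc3cc(CN4C(=O)CCC4=O)sc23)c1O[C@H]1CCCNC1` differs from compound 1 by piperidin-3-yl in place of 3-aminocyclobutyl on an oxygen on an aromatic ring. Within the data shown here, no measured pair shares this change, and compound 1 carries no value, so neither the size nor the direction of the step can be taken from the data; whether it lies within or beyond the scatter is open. Among the measured compounds shown here, for compound 3 the clearance in this assay is estimated at about 50 mL/min/kg, with an expected range from 15 mL/min/kg to 150 mL/min/kg, resting only on the one value of compound 2, which shares part of its structure with compound 1 and compound 3.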

Compound 3, clearance: 81.7 mL/min/kg
Compound 3: the middle estimate sits 1.6-fold (0.21 log units) below what was measured, and the stated range covers the measured number.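

In this assay, within the data shown here, compound 3 gives 81.7 mL/min/kg and compound 1 gives "not determined" (no result reported) so no step between compound 1 and compound 3 can be read. As far as these compounds go, the effect on clearance of piperidin-3-yl in place of 3-aminocyclobutyl stays open. No evidence bears on this result.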